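Furan for chloroaryl: a step from the weakest of three

The source may hold more compounds than are shown below. What is called first, only, known or untested is meant among the compounds shown, and "the series" means these compounds.

Compound 1 `Cc1ccc(C2C(C#N)=C(N)N(c3ccc(S(N)(=O)=O)cc3)C3=C2CCCC3)cc1`: 30%
Compound 2 `N#CC1=C(N)N(c2ccc(S(N)(=O)=O)cc2)C2=C(CCCC2)C1/C=C/c1ccccc1`: 70%
Compound 3 `N#CC1=C(N)N(c2ccc(S(N)(=O)=O)cc2)C2=C(CCCC2)C1c1ccccc1Cl`: 0%

Three compounds share one core and differ only in the group on a saturated ring carbon. In a functional assay on Ehrlich cells (Mus musculus) for cytotoxicity, read by trypan blue exclusion, with a stated time of 2 h, tested at 25 ug/mL (on this read-out higher numbers stand for a stronger effect at the one concentration tested and lower numbers for a weaker effect), compound 1 gives 30%, compound 2 gives 70% and compound 3 gives 0%. Compound 3 stands lowest of the three; its nearest neighbour is compound 1 and its furthest is compound 2. The measured steps onto compound 3 are both downward: a number 30 percentage points lower from compound 1 to compound 3 (beyond the scatter) and a number 70 percentage points lower from compound 2 to compound 3 (beyond the scatter). The step between the other two is a number 40 percentage points higher from compound 1 to compound 2 (beyond the scatter).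

Compound 4 `Cc1ccc(C2C(C#N)=C(N)N(c3ccc(S(N)(=O)=O)cc3)C3=C2CCCC3)o1` has not yet been tested. Its change from compound 3 is 5-methylfuran-2-yl in place of 2-chlorophenyl on a saturated ring carbon. Going by the values given here, no measured step involves a 5-methylfuran-2-yl group, so the two steps onto compound 3 bear only loosely on it: they show that swapping the aryl group moved this assay by modest to large amounts. Since compound 3 sits at the floor, any step can only be upward or none. The closest measured analogue is compound 1, which also carries a methyl on its aryl group and gives 30%. Compound 4 is therefore expected to give 20%, within 0% to 50%, an estimated step of a number 20 percentage points higher from compound 3 to compound 4 (beyond the scatter).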

Compound 4, a percentage reported as activity, at one concentration (the size of the read-out at that concentration, not a potency): 10%
For compound 4 the middle estimate is 10 percentage points above the measured one; low and high end bracket the measured number.
By their numbers in this assay, from the lowest: compounds 3 and 4 (each within the scatter of the next); then compound 1; then compound 2.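

In this assay, putting a five-membered aromatic ring with 1 hetero atom in place of the six-membered 2-chlorophenyl ring gives a number 10 percentage points higher from compound 3 to compound 4 (within the scatter), so 5-methylfuran-2-yl cannot be told apart from 2-chlorophenyl at this saturated ring carbon. A methyl on the aryl group does not by itself bring the level of compound 1, since exchanging 4-methylphenyl for 5-methylfuran-2-yl gives a number 20 percentage points lower from compound 1 to compound 4 (beyond the scatter). The 2-phenylethenyl group stays clearly apart from the newly added furan, with a number 60 percentage points lower from compound 2 to compound 4 (beyond the scatter), so a five-membered aromatic ring carrying an oxygen does not reach the level of that group here.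

Still open, from the compounds shown here alone, is where an unsubstituted furan-2-yl, a pyridine ring or a longer chain ending in an amine would fall at this carbon, and whether the result for compound 2 needs both its phenyl ring and its carbon-carbon double bond. No available evidence accounts for any of these differences.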